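Removing the methoxy from the urea aryl group

The source may hold more compounds than are shown below. What is called first, only, known or untested is meant among the compounds shown, and "the series" means these compounds.

Compound 1 `COc1ccc(NC(=O)Nc2nc(Sc3c[nH]c4ccccc34)cc(N3CCCCC3)n2)cc1` is measured in a functional assay on PC-3 cells (Homo sapiens) for inhibition, with a stated time of 72 h (a higher number here means a weaker inhibitor, a lower number a stronger inhibitor), where compound 1 gives 17400 nM. Two other compounds share its core. Compound 2 `COc1ccc(NC(=O)Nc2nc(Nc3cc(OC)cc(OC)c3)cc(Sc3c[nH]c4ccccc34)n2)cc1` gives 15100 nM in this assay, and compound 3 `Cc1ccc(C)c(NC(=O)Nc2nc(Sc3c[nH]c4ccccc34)cc(N3CCN(Cc4ccccc4)CC3)n2)c1` gives 17300 nM. Within the data shown here, the three numbers sit together: the single counted step, a 1.2-fold lower number from compound 1 to compound 2 (0.06 log units; within the scatter), lies within the scatter, and compound 1 stands apart from neither of the others by more than that.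

Compound 4 `O=C(Nc1ccccc1)Nc1nc(Sc2c[nH]c3ccccc23)cc(N2CCCCC2)n1` has not yet been measured. It differs from compound 1 in one place: hydrogen in place of methoxy on an aromatic carbon. Among the measured compounds shown here, none of the measured steps touches this position; the only counted step, from compound 1 to compound 2, alters a different part of the molecule and changes the number by an amount within the scatter. The change to compound 4 takes away a small group, leaving the rest of compound 1 unchanged. For the measured compounds named here, with no measured step bearing on it, the expectation for compound 4 in this assay is a number close to that of compound 1, with no step beyond the scatter in either direction; the step that this estimate means is a 1.0-fold lower number from compound 1 to compound 4 (0.01 log units; within the scatter). The estimated value for compound 4 is 17000 nM, within a range from 7000 nM to 40000 nM.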

Compound 4, half-maximal inhibitory concentration: 12100 nM
Compound 4: middle estimate off by 1.4-fold (0.15 log units), on the high side; low and high end bracket the measured number.
By their numbers in this assay, from the lowest: compounds 4, 2, 3 and 1 (each within the scatter of the next).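

Among these compounds, compound 4 gives the only reading at this position: in this assay, taking the methoxy off the urea aryl group gives a 1.4-fold lower number from compound 1 to compound 4 (0.16 log units; within the scatter) and so stays inside the usual scatter. The earlier step changed a different part of the molecule, whereas this one shows that the change from 4-methoxyphenyl to phenyl, on an aromatic carbon para to a large group, removes two heavy atoms and one hydrogen-bond acceptor without moving the number beyond the scatter. No measurement is available that accounts for this result or bears on it.

What the compounds shown leave open is whether another group at this position, such as an amine, a carboxylic acid or a longer alkoxy chain, would carry the number beyond the scatter. As far as these compounds go, it is also open whether the same loss of methoxy would read alike in compound 2, which carries (3,5-dimethoxyphenyl)amino in place of piperidin-1-yl, since this single pair speaks only for the piperidin-1-yl series.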